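This account rests on a few compounds, and the source may have more. Where it says the series, first, only, none or still open, it means among the compounds named here.

For the measured compounds named here, compound 2 `N#CC1(NC(=O)[C@@H]2C[C@@H](S(=O)(=O)c3ccccc3)C[C@H]2C(=O)N2CC3CCC(C2)O3)CC1` holds the lowest number of the two compounds measured so far: in an assay on isolated protein for inhibition of cathepsin S (Homo sapiens), read by fluorescence, with a stated time of 20 min (on this read-out higher numbers stand for weaker inhibition and lower numbers for stronger inhibition), compound 2 gives 1 nM, whereas compound 1 `N#CCNC(=O)[C@@H]1C[C@@H](S(=O)(=O)CC2CC2)C[C@H]1C(=O)N1CCOCC1` gives 230 nM, a gap that lies well beyond the usual scatter. The two compounds differ in several places at once, so no single change can be read from that gap. Compound 3 `N#CC1(NC(=O)[C@@H]2C[C@@H](S(=O)(=O)c3ccccc3)C[C@H]2C(=O)N2CCC(O)CC2)CC1` has not yet been measured. It departs from compound 2 in one place only: a group of 7 heavy atoms (5 carbon, 1 nitrogen, 1 oxygen; one six-membered non-aromatic ring with 1 hetero atom) in place of a group of 8 heavy atoms (6 carbon, 1 nitrogen, 1 oxygen; one five-membered non-aromatic ring with 1 hetero atom, one six-membered non-aromatic ring with 2 hetero atoms), on a carbonyl carbon. The rest of compound 2 is kept unchanged. Going by the values given here, no measured pair in this set isolates that change, so its size cannot be taken from the data; the only anchor is the value of compound 2, 1 nM. The step of a 3.0-fold higher number from compound 2 to compound 3 (0.48 log units; beyond the scatter) is expected to be small, toward weaker inhibition if it moves at all, and possibly within the scatter. For compound 3 the estimate in this assay is 3 nM, with a range from 0.8 nM to 15 nM.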

Compound 3, half-maximal inhibitory concentration: 1 nM
Compound 3: the middle estimate sits 3.0-fold (0.48 log units) above what was measured, within the range that was stated.
By their numbers in this assay, from the lowest: compounds 2 and 3 (each within the scatter of the next); then compound 1.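

In this assay, putting 4-hydroxypiperidin-1-yl on the carbonyl carbon in place of the group with a five-membered and a six-membered non-aromatic ring gives no change at the digits printed from compound 2 to compound 3 (within the scatter). For the compounds shown here, this is the first pair in the set that differs in one place only, and it shows that at this position one ring can stand in place of two, and a group with 1 hydrogen-bond donor in place of one with 0, with no difference beyond the scatter. Nothing at hand gives a reason for this outcome.

On these data alone, only these two groups are compared on this carbonyl carbon, so it remains open whether a carboxylic acid, a dimethylamino group or an open chain such as 2-methoxyethyl would also stay within the scatter of compound 2. As far as these compounds go, it also remains open whether the same holds with other groups elsewhere on the shared core, since compound 1 differs from compound 2 and compound 3 in several places and gives no reading of this position.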